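Series notes: amide groups on the aromatic nitrogen

The compounds below may be only part of what the source reports. "The series", "measured", "known", "first", "only" and "open" are said of these compounds alone.

Of the compounds shown here, two have been measured in a functional assay (Oryctolagus cuniculus) for antagonist activity at platelet-activating factor receptor (Cavia porcellus); on this read-out lower numbers stand for stronger inhibition and higher numbers for weaker inhibition. Compound 1 `NC(=O)n1cc(C(=O)c2ccn3c2CSC3c2cccnc2)c2ccc(-c3ccc(F)cc3)cc21` gives 6 nM. Within the data shown here, compound 2 `CN(C)C(=O)Cn1cc(C(=O)c2ccn3c2CSC3c2cccnc2)c2ccc(-c3ccc(F)cc3)cc21` gives 0.7 nM, the lowest of the two numbers at hand; its only neighbour is compound 1, and the step of an 8.6-fold lower number from compound 1 to compound 2 (0.93 log units; beyond the scatter) separates the two. Compound 3 `NNC(=O)n1cc(C(=O)c2ccn3c2CSC3c2cccnc2)c2ccc(-c3ccc(F)cc3)cc21` is not yet measured. It differs from compound 2 in one place: aminocarbamoyl in place of (dimethylcarbamoyl)methyl on an aromatic nitrogen. Among the measured compounds shown here, the single measured step that bears on this change is an 8.6-fold lower number from compound 1 to compound 2 (0.93 log units; beyond the scatter), in which the carbamoyl of compound 1 was exchanged for the (dimethylcarbamoyl)methyl of compound 2. Compound 3 carries aminocarbamoyl, which in its size and in what is counted for it sits nearer the carbamoyl of compound 1 than the group of compound 2. For the measured compounds named here, the expectation for compound 3 is therefore an upward step in this assay of a 7.1-fold higher number from compound 2 to compound 3 (0.85 log units; beyond the scatter), back into the region of the first compound, with the size uncertain given only one measured pair. For compound 3 the estimated value is 5 nM, with a range of 1.5 nM to 15 nM.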

Compound 3, inhibition constant: 25 nM
Compound 3: middle estimate off by 5.0-fold (0.70 log units), on the low side; measured number outside the range, above it.
By their numbers in this assay, from the lowest: compound 2; then compound 1; then compound 3.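

In this assay, adding an amino to the amide-type nitrogen of the carbamoyl group is not a silent change: a 4.2-fold higher number from compound 1 to compound 3 (0.62 log units; beyond the scatter), which lies beyond the scatter, and the order of the three numbers places aminocarbamoyl above carbamoyl rather than level with it. Against the (dimethylcarbamoyl)methyl group the change is larger, a 36-fold higher number from compound 2 to compound 3 (1.55 log units; beyond the scatter), so the spread of numbers at this position on an aromatic nitrogen is wider than the one earlier step showed, and a small edit to the carbamoyl group is enough to widen it. The data at hand offer no explanation for either step.

The compounds shown do not separate the two differences between carbamoyl and (dimethylcarbamoyl)methyl, namely the added carbon link to the aromatic nitrogen and the two methyl groups on the amide nitrogen. A plain carbamoylmethyl group or a dimethylcarbamoyl group would divide that step, and an N-methylaminocarbamoyl group would show whether the rise seen with the amino persists once that amino is substituted.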